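This account rests on a few compounds, and the source may have more. Where it says the series, first, only, none or still open, it means among the compounds named here.

Compound 1 `CCC1(Cc2ccccc2)OS(=O)(=O)C=C1OCC(=O)OC` was examined in an ADME assay on HEL cells (Homo sapiens) for cytotoxicity, with a stated time of 3 days; on this read-out higher numbers stand for lower toxicity in this test and lower numbers for higher toxicity in this test. In this assay compound 1 gives > 200000 nM, which is a limit of the assay rather than a number, a point where one of the three values shown sits (the limit of > 200000 nM in this assay, at which 1 of the 3 values shown sits). Two further compounds carry the same core. Compound 2 `CC1(C(c2ccccc2)c2ccccc2)OS(=O)(=O)C=C1OCc1ccccc1` gives 200000 nM in this assay. Compound 3 `CCC1(Cc2ccccc2)OS(=O)(=O)C=C1OS(=O)(=O)c1ccc(C)cc1` gives 109000 nM in this assay. Going by the values given here, no step between measured compounds differing in a single place has been set down, so of compound 2 and compound 3 one can say only what their two values show, and those values lie close together.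

Compound 4 `CCC1(Cc2ccccc2)OS(=O)(=O)C=C1OCc1ccc(Cl)cc1` has not yet been measured in this assay. It differs from compound 1 by 4-chlorophenyl in place of methoxycarbonyl on a saturated chain carbon bound to an oxygen on an unsaturated carbon; the same difference, cut one bond further out, reads (methoxycarbonyl)methyl to 4-chlorobenzyl. Among the compounds with values here, no measured pair maps this change, so the expectation rests on the values of compound 2 and compound 3 alongside the limit reached by compound 1. The step expected from compound 1 to compound 4 in this assay is an at least 1.3-fold lower number from compound 1 to compound 4 (0.12 log units; that floor lies within the scatter), a modest move toward higher toxicity or none beyond the scatter. Compound 4 is therefore expected to give 150000 nM in this assay, within a range from 60000 nM to 300000 nM.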

Compound 4, half-maximal cytotoxic concentration: > 200000 nM
Compound 4: no number, only a limit; the forecaster's own chance of this, stated with the estimate: 35%; middle value at least 1.3-fold (0.12 log units) from the limit.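

In this assay compound 4 gives > 200000 nM as a limit of the assay, not a number. Going by these compounds alone, compound 1 also stands at a limit, so no step between compound 1 and compound 4 can be read, and both share one ceiling: the limit of > 200000 nM in this assay, at which 2 of the 4 values shown sit. The compounds shown leave open whether (methoxycarbonyl)methyl and 4-chlorobenzyl differ at all in this test.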